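The compounds below may be only part of what the source reports. "The series", "measured", "known", "first", "only" and "open" are said of these compounds alone.

For the measured compounds named here, in a functional assay on K562 cells (Homo sapiens) for inhibition, read by sulforhodamine B assay, with a stated time of 48 h, tested at 10 uM (on this read-out lower numbers stand for less inhibition and higher numbers for more inhibition at the one concentration tested (going by the name of the read-out)), compound 1 `c1cn2cc(-c3ccsc3)nc(-c3ccc4ncn(C5CCCCC5)c4c3)c2n1` gives 22%, and compound 2 `Clc1ccc(-c2cn3ccnc3c(-c3ccc4ncn(C5CCCCC5)c4c3)n2)cc1` gives 44.5%, the higher of the two numbers; the one measured step, a number 22.5 percentage points higher from compound 1 to compound 2 (beyond the scatter), separates them. Compound 3 `Fc1ccccc1-c1cn2ccnc2c(-c2ccc3ncn(C4CCCCC4)c3c2)n1` differs from compound 2 by 2-fluorophenyl in place of 4-chlorophenyl on an aromatic carbon. Going by the values given here, no measured step exchanges one substituted phenyl for another, so the move from thiophen-3-yl to 4-chlorophenyl is only a loose guide, showing that a change on this aromatic carbon can shift the read-out beyond the scatter. Compound 3 is therefore expected to show a number 9.5 percentage points lower from compound 2 to compound 3 (within the scatter), a modest drop. Compound 3 is estimated at 35%, within 15% to 55%.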

Compound 3, a percentage reported as inhibition, at one concentration (the size of the read-out at that concentration, not a potency): 22.8%
Compound 3: the middle estimate sits 12.2 percentage points above what was measured, within the range that was stated.
By their numbers in this assay, from the lowest: compounds 1 and 3 (each within the scatter of the next); then compound 2.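

In this assay, a number 21.7 percentage points lower from compound 2 to compound 3 (beyond the scatter) shows that exchanging one halogen-bearing phenyl group for another on this aromatic carbon can alone move the read-out, so a phenyl group here does not guarantee the higher number. Exchanging thiophen-3-yl for 2-fluorophenyl gives a number 0.8 percentage points higher from compound 1 to compound 3 (within the scatter), so these two groups are not separated here. Nothing given here explains the difference between 4-chlorophenyl and 2-fluorophenyl. Going by these compounds, those two groups differ in both halogen and ring position, so which of these matters stays open. On these data alone, how an amine or a carboxylic acid on that phenyl ring would read also remains open.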